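The source may report more compounds than this note shows. Statements on the series, on what has been measured and on what is new or still open speak of the compounds shown alone.

In a functional assay on L1210 cells (Mus musculus), with a stated time of 1 days (on this read-out higher numbers stand for higher potency (the scale is a negative logarithm) and lower numbers for lower potency), compound 1 `CC1=C(N2CC2)C(=O)C(Cc2ccccc2)=C(N2CC2)C1=O` gives 4.26, which places it second highest of the three numbers measured. Compound 3 `CCCC1=C(N2CC2)C(=O)C(CCC)=C(N2CC2)C1=O` gives 4.14, a number that lies within the scatter of compound 1. Compound 2 `CCOC(COC(N)=O)C1=C(N2CC2)C(=O)C(C)=C(N2CC2)C1=O` gives 4.62, a number beyond the scatter above compound 1. Compound 4 `COC(CO)C1=C(N2CC2)C(=O)C(C)=C(N2CC2)C1=O` has not yet been measured in this assay. It differs from compound 1 in one place: 2-hydroxy-1-methoxyethyl in place of benzyl on a double-bonded ring carbon. Going by the values given here, no step between measured compounds that differ in one place is known here, so the size of this change can only be guessed. Because compound 2 gives 4.62 with a related side chain, a small upward step of a number 0.24 log units higher from compound 1 to compound 4 (within the scatter) is expected. Compound 4 is estimated at 4.5, with a range from 4.1 to 4.9.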

Compound 4, logarithm of the reciprocal of the active concentration, log(1/C): 5.27
Beside the measured number, compound 4's estimate is 0.77 log units below it; measured number outside the range, above it.
By their numbers in this assay, from the lowest: compounds 3 and 1 (each within the scatter of the next); then compound 2; then compound 4.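

In this assay, putting 2-hydroxy-1-methoxyethyl in place of benzyl on this double-bonded ring carbon gives a large step, a number 1.01 log units higher from compound 1 to compound 4 (beyond the scatter). Going by these compounds alone, this is the first single-place change that can be read, and it shows that this position is sensitive to its substituent and that a six-membered aromatic ring is not needed there for this potency. Nothing available accounts for the rise. The compounds shown leave open whether the hydroxyl, the methoxy or the loss of benzyl matters most, and how an amine or a carboxylic acid on this side chain would fare.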